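The source may hold more compounds than are shown below. What is called first, only, known or untested is meant among the compounds shown, and "the series" means these compounds.

Measured so far:
compound 1 `O=CNc1ccc(C2=NNC(=O)CC2)cc1`: 3.74 ug/mL
compound 2 `CN1N=C(c2ccc(N)cc2)CCC1=O`: > 46.4 ug/mL
compound 3 `CC1CC(c2ccc(NC(=O)CCl)cc2)=NNC1=O`: 21.9 ug/mL

In a functional assay for inhibition, with Homo sapiens as the target (a lower number here means that less compound is needed, a higher number that more compound is needed for the effect), compound 1 gives 3.74 ug/mL, the lowest of the two numbers. Its nearest neighbour, compound 3, gives 21.9 ug/mL, a higher number, and that gap lies beyond the usual scatter. For compound 2 the assay reports only a limit, > 46.4 ug/mL; this is the limit of > 46.4 ug/mL in this assay, at which 1 of the 3 values shown sits. Compound 4 `CCCNCC(=O)Nc1ccc(C2=NNC(=O)CC2)cc1` has not yet been measured. It differs from compound 1 in one place: (propylamino)methyl in place of hydrogen on a carbonyl carbon. For the measured compounds named here, no two measured compounds differ in just one place, so no measured step guides this change. The step is expected to be a moderate rise, a 2.7-fold higher number from compound 1 to compound 4 (0.43 log units; beyond the scatter). Compound 4 is therefore estimated at 10 ug/mL, within a range from 3 ug/mL to 35 ug/mL.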

Compound 4, half-maximal effective concentration: about 46.4 ug/mL
The estimate for compound 4 lay 4.6-fold (0.67 log units) below the measured number; the measured number lies above the stated range.
By their numbers in this assay, from the lowest: compound 1; then compound 3; then compound 4.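

Putting (propylamino)methyl in place of hydrogen on the carbonyl carbon brings a 12-fold higher number from compound 1 to compound 4 (1.09 log units; beyond the scatter) in this assay, so what sits at this place clearly matters. Of the two groups compared here, hydrogen gives the lower number. Compound 2 has only a limit, not a number, and the number for compound 4 stands level with it: the limit of > 46.4 ug/mL in this assay, at which 1 of the 4 values shown sits.

Open, as far as these compounds go, is whether a plain methyl on the same carbonyl carbon would keep the number close to that of compound 1. Also open, from the compounds shown here alone, is whether a longer chain without an amine would raise it as much.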